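Nitro to chloro on the aromatic ring of compound 3

The source may report more compounds than this note shows. Statements on the series, on what has been measured and on what is new or still open speak of the compounds shown alone.

The shared core is that of compound 1 `CC1=CC[C@@H]([C@@](C)(O)CCCC(C)(C)NC(=S)NN)CC1`. In a functional assay on PCO3 cells (Homo sapiens) for cytotoxicity, read by sulforhodamine B assay (a lower number here means a stronger inhibitor of growth, a higher number a weaker inhibitor of growth), compound 1 reaches only the assay limit, > 100000 nM. Compound 2 `CC1=CC[C@@H]([C@@](C)(O)CCCC(C)(C)NC(=S)N/N=C\c2ccc(C)cc2)CC1` carries the added aromatic group with methyl; in this assay compound 2 gives 45700 nM, and the step is an at least 2.1-fold lower number from compound 1 to compound 2 (0.34 log units; beyond the scatter). Compound 3 `CC1=CC[C@@H]([C@@](C)(O)CCCC(C)(C)NC(=S)N/N=C\c2ccc([N+](=O)[O-])cc2)CC1` has nitro in place of that methyl. In this assay compound 3 again returns only the limit, > 100000 nM. Accordingly an at least 2.1-fold higher number from compound 2 to compound 3 (0.34 log units; beyond the scatter); compound 3 stands at the limit of > 100000 nM in this assay, at which 2 of the 3 values shown sit, so only one side of its value is known.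

Compound 4 `CC1=CC[C@@H]([C@@](C)(O)CCCC(C)(C)NC(=S)N/N=C\c2ccc(Cl)cc2)CC1` differs from compound 3 by chloro in place of nitro on an aromatic carbon. For the measured compounds named here, no measured step carries chloro anywhere. For compound 4 the estimated step is an at least 1.4-fold lower number from compound 3 to compound 4 (0.15 log units; that floor lies within the scatter), because an at least 2.1-fold higher number from compound 2 to compound 3 (0.34 log units; beyond the scatter) went from a number to a limit and chloro is an untested third substituent at that carbon. Compound 4 is estimated at 70000 nM, from 30000 nM to 150000 nM, with a fair chance that in this assay compound 4 again reports only the limit.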

Compound 4, concentration for total growth inhibition: 22700 nM
For compound 4 the middle estimate is 3.1-fold (0.49 log units) above the measured one; measured number outside the range, below it.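

Chloro at this aromatic carbon returns a measured number where nitro does not, an at least 4.4-fold lower number from compound 3 to compound 4 (0.64 log units; beyond the scatter), so the limit seen with nitro does not extend to every replacement of methyl here. Against methyl, chloro gives no separable result, a 2.0-fold lower number from compound 2 to compound 4 (0.30 log units; within the scatter), so these two substituents cannot be ranked in this assay. The aromatic group carrying chloro also improves on the unsubstituted hydrazine end of the series, an at least 4.4-fold lower number from compound 1 to compound 4 (0.64 log units; beyond the scatter), which makes methyl and chloro the two cases of a gain with nitro going against them, though the steps involving the two limit compounds are one-sided: the limit of > 100000 nM in this assay, at which 2 of the 4 values shown sit.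

On these data alone, what a methoxy group, an amine or fluoro at this aromatic carbon would give remains open. Also open, as far as these compounds go, is whether the result for nitro stands alone, since only three substituents at this carbon can be compared.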